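A few compounds are considered here, and "the series" means these few. Any claim that something is new, unique, unknown or untested is made for them only; others in the source may bear on it.

The series shares one core; compound 1 `COc1cc(-c2nnc3n2NC(c2cccs2)C(C(=O)c2ccc(C)cc2)S3)cc(OC)c1OC` carries a 4-methylphenyl on the carbonyl carbon, and in a functional assay on HepG2 cells (Homo sapiens) for cytotoxicity, read by MTT assay, with a stated time of 48 h (on this read-out lower numbers stand for stronger inhibition and higher numbers for weaker inhibition), compound 1 gives 3700 nM. Compound 2 `COc1cc(-c2nnc3n2NC(c2ccco2)C(C(=O)c2ccc(F)c(F)c2)S3)cc(OC)c1OC` gives 52400 nM. Compound 3 `COc1cc(-c2nnc3n2NC(c2ccco2)C(C(=O)c2cccc(Br)c2)S3)cc(OC)c1OC` reaches only the limit of the assay, > 100000 nM, so no number is known for it; it sits at the limit of > 100000 nM in this assay, at which 1 of the 3 values shown sits, the weakest reading among the three. Among the measured compounds shown here, the one measured step at the same place, an at least 1.9-fold higher number from compound 2 to compound 3 (0.28 log units; that floor lies within the scatter), runs into that limit and is itself within the scatter. Compound 4 `COc1cc(-c2nnc3n2NC(c2ccco2)C(C(=O)c2ccc(C)cc2)S3)cc(OC)c1OC` differs from compound 3 as follows: 4-methylphenyl in place of 3-bromophenyl on a carbonyl carbon. Only compound 1 shows how a 4-methylphenyl on this carbonyl fares, and there it gives 3700 nM, though compound 1 also differs from compound 4 in the five-membered ring. On that basis the step of an at least 6.6-fold lower number from compound 3 to compound 4 (0.82 log units; beyond the scatter) is expected to be a lower number, beyond the scatter. Compound 4 is therefore estimated at 15000 nM, with a range from 3000 nM to 100000 nM.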

Compound 4, half-maximal inhibitory concentration: 17400 nM
Estimate against measurement, compound 4: 1.2-fold (0.06 log units) below; the range from low to high includes it.
By their numbers in this assay, from the lowest: compound 1; then compound 4; then compound 2. At a limit, above all of these: compound 3.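

With the furan-2-yl held constant, the group on the carbonyl carbon now shows a readable effect: the change gives an at least 5.7-fold lower number from compound 3 to compound 4 (0.75 log units; beyond the scatter), and it also gives a 3.0-fold lower number from compound 2 to compound 4 (0.48 log units; beyond the scatter). Compound 3 stands at a limit, so the first of these steps is only a floor: the limit of > 100000 nM in this assay, at which 1 of the 4 values shown sits. Among the compounds shown here, compound 4 also supplies the first comparison that isolates the other varied group, with furan-2-yl in place of thiophen-2-yl on a saturated ring carbon giving a 4.7-fold higher number from compound 1 to compound 4 (0.67 log units; beyond the scatter).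

The change from 3-bromophenyl to 4-methylphenyl alters both the substituent and where it sits, so a 3-methylphenyl or 4-bromophenyl would be needed to separate the two. Whether thiophen-2-yl has the same effect alongside 3,4-difluorophenyl or 3-bromophenyl also remains open, since that exchange is shown for only one pair.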